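Swapping the acyl group of compound 2 for a urea

The source may report more compounds than this note shows. Statements on the series, on what has been measured and on what is new or still open speak of the compounds shown alone.

Measured compounds in an assay on HEK293 cells for negative allosteric modulation of metabotropic glutamate receptor 5 (Homo sapiens), read by FLIPR, with a stated time of 1 h; a lower number here means a stronger inhibitor, a higher number a weaker inhibitor:
Compound 1 `Fc1cccc(C#Cc2nc3c(s2)CN(C2CCOC2)CC3)c1` gives 400 nM.
Compound 2 `O=C(C1CC12CCC2)N1CCc2nc(C#Cc3ccccc3)sc2C1` sits at the limit of the assay, > 10000 nM.
Compound 3 `O=C(C1CC(F)(F)C1)N1CCc2nc(C#Cc3cccc(F)c3)sc2C1` also sits at the limit of the assay, > 10000 nM.

Compound 2 therefore stands at the weak end of the numbers shown, with only a limit and no exact value; it shares this with compound 3 (the limit of > 10000 nM in this assay, at which 2 of the 3 values shown sit). Among the compounds with values here, the one step between measured compounds that differ in a single place is an at least 25-fold higher number from compound 1 to compound 3 (1.39 log units; beyond the scatter), where a carbonyl-bearing group entered on the amine nitrogen in a ring. Compound 2 already carries such a carbonyl group.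

Compound 4 `O=C(N1CCCCC1)N1CCc2nc(C#Cc3ccccc3)sc2C1` differs from compound 2 only on that carbonyl carbon: a group of 6 heavy atoms (5 carbon, 1 nitrogen; one six-membered non-aromatic ring with 1 hetero atom) in place of a group of 6 heavy atoms (6 carbon; one three-membered non-aromatic ring of carbon only, one four-membered non-aromatic ring of carbon only), on a carbonyl carbon. Both groups carry a carbonyl on the same ring nitrogen, so this change does not retrace the measured step; it only trades one carbonyl substituent for another of the same size. Within the data shown here, no measured step shows what such a trade does, so a step no larger than the scatter is expected, and compound 4 is expected to remain near the limit, a step that the limit leaves unreadable from compound 2 to compound 4. For compound 4 in this assay the estimate is 12000 nM, within 3000 nM to 40000 nM.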

Compound 4, half-maximal inhibitory concentration: > 10000 nM
Compound 4: no number, only a limit; the forecaster's own chance of this, stated with the estimate: 70%; the middle value is on the limit's open side.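

In this assay compound 4 gives > 10000 nM, which is a limit of the assay and not a number. Compound 2 also has only a limit, so no step can be read between compound 2 and compound 4. The compounds shown leave open how strongly either one inhibits, and whether the group on the carbonyl carbon matters at all.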